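Catechol-bearing thiadiazole amides: acyl variation toward cyclohexyl

The source may hold more compounds than are shown below. What is called first, only, known or untested is meant among the compounds shown, and "the series" means these compounds.

Measured compounds in a functional assay on HL-60 cells (Homo sapiens) for cytotoxicity, read by MTT assay, with a stated time of 72 h; a higher number here means a weaker inhibitor, a lower number a stronger inhibitor:
Compound 1 `O=C(Nc1nnc(-c2cccc(O)c2O)s1)c1ccccc1` gives 20700 nM.
Compound 2 `O=C(Nc1nnc(-c2ccc(O)c(O)c2)s1)c1ccc(Cl)cc1` gives 14700 nM.

Two amides on a shared core have been measured. Compound 2 carries the smaller of the two numbers in this assay, with compound 1 nearest; the gap between them lies within the usual scatter, so the two cannot be separated on these data. Among the measured compounds shown here, no step between measured compounds that differ in one place exists, so nothing is known yet about how a change at the acyl side moves the read-out.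

Compound 3 `O=C(Nc1nnc(-c2ccc(O)c(O)c2)s1)C1CCCCC1` is the next member to be measured in this assay. It differs from compound 2 by cyclohexyl in place of 4-chlorophenyl on a carbonyl carbon. For the measured compounds named here, with no comparable step on record, the working expectation is that the change from compound 2 to compound 3 produces no shift beyond the scatter, a 1.2-fold higher number from compound 2 to compound 3 (0.09 log units; within the scatter) being the estimated step. Compound 3 is therefore expected near 18000 nM, within a range of 6000 nM to 55000 nM.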

Compound 3, half-maximal inhibitory concentration: 8800 nM
Compound 3: the middle estimate sits 2.0-fold (0.31 log units) above what was measured; the range from low to high includes it.
By their numbers in this assay, from the lowest: compounds 3, 2 and 1 (each within the scatter of the next, the first and the last beyond it).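

In this assay, the series now has its first one-place step, a 1.7-fold lower number from compound 2 to compound 3 (0.22 log units; within the scatter), so cyclohexyl in place of 4-chlorophenyl on a carbonyl carbon gives a read-out that cannot be separated from that of compound 2. For this pair, then, an aromatic ring at this position is not needed for a read-out in this range, though the chlorine leaves together with the ring, so the two parts of the swap cannot be told apart. No measurement on hand bears on why the two groups read alike.

Still open, going by these compounds, is whether any group on this carbonyl carbon moves the number beyond the scatter. A methyl, a longer alkyl chain or a cyclohexyl carrying an amine or a carboxylic acid would test how far this position can be changed.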